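The source may report more compounds than this note shows. Statements on the series, on what has been measured and on what is new or still open speak of the compounds shown alone.

Three ureas built on closely related cores were tested in a functional assay on NCI-H1581 cells (Homo sapiens) for inhibition, read by MTT assay, with a stated time of 48 h, tested at 10 uM; on this read-out lower numbers stand for less inhibition and higher numbers for more inhibition at the one concentration tested (going by the name of the read-out). In this assay compound 1 `COc1cc(NC(=O)Nc2cc(Nc3ccc(C(C)(C)C)cc3)ncn2)cc(OC)c1` gives 38.7%. Compound 3 `COc1cc(NC(=O)Nc2cc(Nc3cc(F)ccc3OC)ncn2)cc(OC)c1` gives 42.1% in this assay, and compound 2 `COc1ccc(F)cc1Nc1cc(NC(=O)Nc2c(Cl)cccc2Cl)ncn1` gives 73.1%. The cores of compound 3 and compound 1 differ by 4-(tert-butyl)phenyl in place of 5-fluoro-2-methoxyphenyl on a nitrogen on an aromatic ring, and this gave a number 3.4 percentage points higher from compound 1 to compound 3 (within the scatter). The change that mattered was 2,6-dichlorophenyl in place of 3,5-dimethoxyphenyl on an amide-type nitrogen, which gave a number 31 percentage points higher from compound 3 to compound 2 (beyond the scatter). Compound 4 `CC(C)(C)c1ccc(Nc2cc(NC(=O)Nc3c(Cl)cccc3Cl)ncn2)cc1` has not been measured in this assay. It differs from compound 1 by 2,6-dichlorophenyl in place of 3,5-dimethoxyphenyl on an amide-type nitrogen; the place is the same word for word as in the change from compound 3 to compound 2, so it is the same change carried onto the core of compound 1. Its step is expected to be about as large, a number 30.3 percentage points higher from compound 1 to compound 4 (beyond the scatter), because the same change earlier gave a number 31 percentage points higher from compound 3 to compound 2 (beyond the scatter) and the two starting compounds sit within the scatter of each other. Compound 4 is therefore estimated at 69% in this assay, with an expected range from 52% to 84%.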

Compound 4, a percentage reported as inhibition, at one concentration (the size of the read-out at that concentration, not a potency): 71.3%
Compound 4: middle estimate off by 2.3 percentage points, on the low side; the range from low to high includes it.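

In this assay, 2,6-dichlorophenyl in place of 3,5-dimethoxyphenyl on an amide-type nitrogen gave a number 32.6 percentage points higher from compound 1 to compound 4 (beyond the scatter) and so kept its size on the second core, with the two steps agreeing: the same change on two cores in this assay, a number 31 percentage points higher (beyond the scatter) from compound 3 to compound 2 and a number 32.6 percentage points higher (beyond the scatter) from compound 1 to compound 4, 1.6 percentage points apart, within the scatter of two such steps. Within this series, then, the change carried from the core of compound 3 to the core of compound 1 with no sign that the group on the aromatic-ring nitrogen altered its effect, whether that group was 5-fluoro-2-methoxyphenyl or 4-(tert-butyl)phenyl. This rests on just two cores and one concentration, so it does not show that the step would hold on other cores, how potency shifts, or why the change raises the number.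

The compounds shown leave open whether both chlorine atoms are needed, since no phenyl with a single chlorine and no unsubstituted phenyl appears on the amide-type nitrogen. They also leave open whether the step survives when an amine such as morpholine sits on the aromatic-ring nitrogen in place of these aryl groups.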